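The compounds below may be only part of what the source reports. "The series", "measured", "known", "first", "only" and "open" are said of these compounds alone.

Compound 1 `C[C@@H]1CCCN1c1c(C#N)c2c(N)nc(Nc3cn(C)nc3Cl)nc2n1C`: 21 nM
Compound 2 `Cc1c(Nc2nc(N)c3c(C#N)c(N4CCC[C@H]4C)n(C)c3n2)cnn1C1COC1`: 37 nM

In an assay on isolated protein for inhibition of Leucine-rich repeat serine/threonine-protein kinase 2 variant G2019S (Homo sapiens), read by TR-FRET and LanthaScreen, with stated times of 50 min and 30 min, in the presence of a further agent that is not named here (a lower number here means a stronger inhibitor, a higher number a weaker inhibitor), compound 2 gives the highest of the two numbers, though the step of a 1.8-fold higher number from compound 1 to compound 2 (0.25 log units; within the scatter) is within the scatter, so compounds 1 and 2 are not distinguished. Compound 3 `C[C@@H]1CCCN1c1c(C#N)c2c(N)nc(N)nc2n1C` has not been measured; it differs from compound 2 by hydrogen in place of 5-methyl-1-(oxetan-3-yl)-1H-pyrazol-4-yl on a nitrogen on an aromatic ring. Within the data shown here, the only measured step, from compound 1 to compound 2, exchanges one pyrazolyl group for another and does not show what the loss of the whole group does. The step of a 27-fold higher number from compound 2 to compound 3 (1.43 log units; beyond the scatter) is therefore expected to be a clear weakening, beyond the scatter, with uncertainty wide in both directions. Compound 3 is estimated at 1000 nM, within 200 nM to 6000 nM.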

Compound 3, half-maximal inhibitory concentration: 217 nM
Compound 3: the middle estimate sits 4.6-fold (0.66 log units) above what was measured; the measured number falls inside the stated range.
By their numbers in this assay, from the lowest: compounds 1 and 2 (each within the scatter of the next); then compound 3.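

In this assay, hydrogen in place of 5-methyl-1-(oxetan-3-yl)-1H-pyrazol-4-yl on a nitrogen on an aromatic ring gives a 5.9-fold higher number from compound 2 to compound 3 (0.77 log units; beyond the scatter) and hydrogen in place of 3-chloro-1-methyl-1H-pyrazol-4-yl gives a 10-fold higher number from compound 1 to compound 3 (1.01 log units; beyond the scatter), so removing either group, unlike exchanging one for the other, weakens inhibition beyond the scatter. Even without either group, compound 3 gives 217 nM as a measurable value. No evidence is available to explain this loss. Going by these compounds, whether a methyl or phenyl group on this nitrogen would bring the number closer to that of compound 1 or compound 3 remains open.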